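Oxadiazole in place of propylamino on the pyridyl-bearing core

The source may hold more compounds than are shown below. What is called first, only, known or untested is meant among the compounds shown, and "the series" means these compounds.

Compound 1 `Cc1cccnc1-c1ccc(C(=O)Nc2ccc(C(F)(F)F)cc2)cc1` gives 65 nM in a functional assay for antagonist activity at transient receptor potential cation channel subfamily V member 1 (Homo sapiens), read by FLIPR; a lower number here means a stronger inhibitor, a higher number a weaker inhibitor. Compound 2 `CCCNc1cccnc1-c1ccc(C(=O)Nc2ccc(C(C)(C)C)cc2)cc1` gives 158 nM in this assay, the higher of the two numbers shown, and its gap to compound 1 lies beyond the usual scatter of repeated measurements. Compound 3 `CC(C)(C)c1ccc(NC(=O)c2ccc(-c3ncccc3-c3nnco3)cc2)cc1` has not yet been measured. It differs from compound 2 in a single place: 1,3,4-oxadiazol-2-yl in place of propylamino on an aromatic carbon. For the measured compounds named here, no pair of measured compounds that differ only in this way is available, so the two values of compound 1 and compound 2 are all that frames the expectation. The step of a 1.3-fold lower number from compound 2 to compound 3 (0.12 log units; within the scatter) is expected to be small, with no clear direction beyond the scatter, since nothing measured speaks for or against the new group. Compound 3 is therefore estimated at 120 nM in this assay, with a range from 40 nM to 400 nM.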

Compound 3, half-maximal inhibitory concentration: 91 nM
Beside the measured number, compound 3's estimate is 1.3-fold (0.12 log units) above it; the measured number falls inside the stated range.
By their numbers in this assay, from the lowest: compounds 1, 3 and 2 (each within the scatter of the next, the first and the last beyond it).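

In this assay, exchanging propylamino for 1,3,4-oxadiazol-2-yl on this aromatic carbon, ortho to a large group and two atoms from the ring nitrogen, gives a 1.7-fold lower number from compound 2 to compound 3 (0.24 log units; within the scatter). This position therefore accepts a five-membered aromatic ring with 3 hetero atoms and 0 hydrogen-bond donors in place of an open chain that carries a donor, with no change beyond the scatter, so that donor is not needed to keep the number at this level. No measurement at hand explains why the two groups read alike.

Compound 1 differs from compound 2 and compound 3 in more than one place, so the contributions of its methyl and trifluoromethyl groups cannot be read from these numbers. From the compounds shown here alone, it remains open how a primary amine, a carboxylic acid or a morpholine ring would read on this same carbon.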